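The source may report more compounds than this note shows. Statements on the series, on what has been measured and on what is new or still open speak of the compounds shown alone.

Measured so far in a functional assay on L1210 cells (Mus musculus) for cytotoxicity, with a stated time of 48 h; a lower number here means a stronger inhibitor, a higher number a weaker inhibitor:
compound 1 `CN(C)c1ccc(/C=C2\CCC/C(=C\c3ccccc3[N+](=O)[O-])C2=O)cc1` gives 164000 nM;
compound 2 `O=C1CCCC/C1=C\c1ccccc1[N+](=O)[O-]` gives 23800 nM;
compound 3 `COc1ccc(/C=C2\CCC/C(=C\c3ccccc3[N+](=O)[O-])C2=O)cc1` gives 42400 nM.

On these numbers compound 3 stands second highest of the three: compound 2 lies within the scatter of it, while compound 1 sits beyond the scatter above it, as the step of a 3.9-fold lower number from compound 1 to compound 3 (0.59 log units; beyond the scatter) shows. Compound 4 `O=C1/C(=C/c2ccccc2)CCC/C1=C\c1ccccc1[N+](=O)[O-]` has not been measured; it differs from compound 3 by hydrogen in place of methoxy on an aromatic carbon. Within the data shown here, only one measured step bears on this change, a 3.9-fold lower number from compound 1 to compound 3 (0.59 log units; beyond the scatter), which exchanged the group on the same aromatic carbon and gave a modest lowering. Compound 4 is expected to give a lower number again in this assay, a modest step of about a 1.7-fold lower number from compound 3 to compound 4 (0.23 log units; within the scatter). The estimate for compound 4 is 25000 nM, ranging from 10000 nM to 60000 nM.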

Compound 4, half-maximal inhibitory concentration: 4840 nM
Estimate against measurement, compound 4: 5.2-fold (0.71 log units) above, outside the stated range (below it).
By their numbers in this assay, from the lowest: compound 4; then compounds 2 and 3 (each within the scatter of the next); then compound 1.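

In this assay the change to 4-methoxyphenyl's bare counterpart, phenyl, gives an 8.8-fold lower number from compound 3 to compound 4 (0.94 log units; beyond the scatter) and the exchange of dimethylamino for hydrogen gives a 34-fold lower number from compound 1 to compound 4 (1.53 log units; beyond the scatter). Among these compounds, the earlier compounds showed only that one group on this aromatic carbon differed from another; now both groups go with a higher number than hydrogen, so the carbon carrying neither gives the lowest number of these three. Nothing measured here explains this. The compounds shown leave open whether a methyl group or a chlorine atom on this carbon would stay close to compound 4 or rise towards compound 3.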